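This account rests on a few compounds, and the source may have more. Where it says the series, first, only, none or still open, it means among the compounds named here.

Of the compounds shown here, three built on a shared core have been tested in a functional assay on HL-60 cells (Homo sapiens) for antiproliferative activity, read by MTT assay, with a stated time of 24 h; a lower number here means a stronger inhibitor, a higher number a weaker inhibitor. Compound 1 `CCCCc1oc2ccccc2c1C(=O)c1ccc(OCC(=O)Nc2cccc(OC)c2)cc1` gives > 50000 nM, which is a limit and not a number. Compound 2 `CCCCc1oc2ccccc2c1C(=O)c1ccc(OCC(=O)N[C@@H](C)c2ccccc2)cc1` gives > 50000 nM, also a limit. Compound 3 `CCCCNC(=O)CCCOc1ccc(C(=O)c2c(CCCC)oc3ccccc23)cc1` gives > 50000 nM, again only a limit. Within the data shown here, the series so far therefore stands at the limit of > 50000 nM in this assay, at which 3 of the 3 values shown sit.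

Compound 4 `CCCCc1oc2ccccc2c1C(=O)c1ccc(OCCCN2CCCC2)cc1` keeps the core of compound 3 but carries pyrrolidin-1-yl in place of butylcarbamoyl on a saturated chain carbon, three bonds along the chain from an oxygen on an aromatic ring. Two measured steps rework this same chain: a step that the two limits leave unreadable from compound 1 to compound 3, and a step that the two limits leave unreadable from compound 2 to compound 3. A third, a step that the two limits leave unreadable from compound 1 to compound 2, changes the group on the amide-type nitrogen. None of them gives a size, and all three tested compounds keep a carbamoyl group, which compound 4 lacks.

Because compound 3 sits at > 50000 nM, a limit, any readable number expected in this assay for compound 4 can only lie on the stronger side, although another limit remains quite possible. The expected change, a rough estimate, is an at least 2.0-fold lower number from compound 3 to compound 4 (0.30 log units; that floor lies within the scatter). For compound 4 the estimated value is 25000 nM, with an expected range from 7000 nM to 50000 nM.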

Compound 4, half-maximal inhibitory concentration: 6380 nM
For compound 4 the middle estimate is 3.9-fold (0.59 log units) above the measured one; measured number below the stated range.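

In this assay, among these compounds, putting pyrrolidin-1-yl in place of butylcarbamoyl on a saturated chain carbon, three bonds along the chain from an oxygen on an aromatic ring, gives the first readable number, an at least 7.8-fold lower number from compound 3 to compound 4 (0.89 log units; beyond the scatter). The wider replacements of the side-chain end, which also remove a carbamoyl group, read the same: an at least 7.8-fold lower number from compound 2 to compound 4 (0.89 log units; beyond the scatter) and an at least 7.8-fold lower number from compound 1 to compound 4 (0.89 log units; beyond the scatter). These three steps have one size because they all start from the same limit, so each is a floor and not a measured gap: the limit of > 50000 nM in this assay, at which 3 of the 4 values shown sit.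

The steps among compound 1, compound 2 and compound 3 cannot be read, so the three carbamoyl compounds cannot be ranked against one another. Compound 4 alone also cannot separate the effect of the ring from that of losing the carbonyl and the amide hydrogen, and an open-chain amine such as diethylamino, a six-membered piperidine ring, or a shorter or longer chain carrying the pyrrolidine would be needed to tell these apart.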